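A few compounds are considered here, and "the series" means these few. Any claim that something is new, unique, unknown or untested is made for them only; others in the source may bear on it.

Of the compounds shown here, three sharing one core have been tested in a physicochemical assay for solubility, in phosphate buffer, with a stated time of 2 h, at pH 7.4; a higher number here means a more soluble compound, a lower number a less soluble compound: compound 1 `Clc1ccc(Nc2nc(-c3ccccn3)cs2)nc1`, compound 2 `Clc1ccc(Nc2nc(-c3cccnn3)cs2)nc1` and compound 3 `Clc1ccc(Nc2nc(-c3cccnn3)c(Cl)s2)nc1`. Within the data shown here, compound 2 gives 20000 nM, the only true number among them. Compound 1 gives < 10000 nM, which is a limit of the assay and not a number. Compound 3 gives < 10000 nM, which is also a limit.

The compound still to be measured is compound 4 `Clc1ccc(Nc2nc(-c3ncccn3)cs2)nc1`. It has the same atoms as compound 2, joined differently, with pyrimidin-2-yl in place of pyridazin-3-yl on an aromatic carbon.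

The closest measured step is an at least 2.0-fold higher number from compound 1 to compound 2 (0.30 log units; that floor lies within the scatter), which also swaps the group on that carbon. A second step, an at least 2.0-fold lower number from compound 2 to compound 3 (0.30 log units; that floor lies within the scatter), adds chloro in place of hydrogen on an aromatic carbon, so it bears less directly on this change. Each of these sizes is only a floor, and each floor lies within the scatter, so neither gives a firm size to carry over. No step beyond the scatter is therefore expected in this assay. The expectation leans slightly downward, as compound 1 and compound 3 both stopped at the limit of < 10000 nM in this assay, at which 2 of the 3 values shown sit.

The estimated change is a 1.4-fold lower number from compound 2 to compound 4 (0.15 log units; within the scatter), which stays within the scatter. For compound 4 the expected value is 14000 nM, with an estimated range from 5000 nM to 35000 nM.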

Compound 4, solubility: 20000 nM
The estimate for compound 4 lay 1.4-fold (0.15 log units) below the measured number; the measured number falls inside the stated range.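

In this assay, the swap of pyridazin-3-yl for pyrimidin-2-yl gives no change at the digits printed from compound 2 to compound 4 (within the scatter), so at this position, on an aromatic carbon next to the ring nitrogen, joining the same atoms differently leaves the read-out where it was. Compound 4 also gives a second comparison with the pyridin-2-yl group, an at least 2.0-fold higher number from compound 1 to compound 4 (0.30 log units; that floor lies within the scatter), and this matches the earlier step to compound 2, with the same floor inside the scatter. On these data alone, compound 1 gives < 10000 nM, which is a limit of the assay and not a number, so the true size of that step remains unknown.

How far the pyridin-2-yl compound really lies from the two compounds with 2 hetero atoms in this ring stays unresolved, because a limit gives only a floor for any step that starts from it: the limit of < 10000 nM in this assay, at which 2 of the 4 values shown sit. Also open, as far as these compounds go, is how this position would respond to a group of a different kind, such as a morpholine ring, a simple amine or a carboxylic acid, in place of these six-membered aromatic rings.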